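The compounds below may be only part of what the source reports. "The series", "measured", "known", "first", "only" and "open" are said of these compounds alone.

Measured compounds:
compound 1 `CC(C)(C)NC(=O)CN(CCCCCC(=O)NO)C(=O)c1ccccc1` gives 42400 nM
compound 2 `O=C(CCCCCN(CC(=O)NC1CCCCC1)C(=O)c1ccccc1)NO` gives 8210 nM
compound 3 `CC(C)(C(=O)NC1CCCCC1)N(CCCCCC(=O)NO)C(=O)c1ccccc1` gives 281000 nM

All three values come from a functional assay on A2780cisR cells (Homo sapiens) for cytotoxicity, read by MTT assay, with a stated time of 72 h; a higher number here means a weaker inhibitor, a lower number a stronger inhibitor. Compound 2 holds the lowest number of the three; compound 3 the highest, with compound 1 in between. The difference between the core of compound 2 and the core of compound 3 is not broken down here.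

Compound 4 `CC(C)(C)NC(=O)C(C)(C)N(CCCCCC(=O)NO)C(=O)c1ccccc1` has not been measured. It is reached from compound 3 by one change: tert-butyl in place of cyclohexyl on an amide-type nitrogen. The same change is already known between two measured compounds, as tert-butyl in place of cyclohexyl on an amide-type nitrogen, where it gave a 5.2-fold higher number from compound 2 to compound 1 (0.71 log units; beyond the scatter).

For compound 4 a step of similar direction is expected, a 2.8-fold higher number from compound 3 to compound 4 (0.45 log units; beyond the scatter), resting on compound 1 against compound 2 in this assay, a 5.2-fold higher number from compound 2 to compound 1 (0.71 log units; beyond the scatter); since compound 3 already sits very high, this assay may report only a limit. The estimate for compound 4 in this assay is 800000 nM, between 200000 nM and 3000000 nM.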

Compound 4, half-maximal inhibitory concentration: 579000 nM
Compound 4: middle estimate off by 1.4-fold (0.14 log units), on the high side, within the range that was stated.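

In this assay, tert-butyl in place of cyclohexyl on an amide-type nitrogen goes the same way on the second core, with a 2.1-fold higher number from compound 3 to compound 4 (0.31 log units; beyond the scatter). Going by these compounds alone, the two steps cannot be told apart in size, so the change carries over between these two cores: the same change on two cores in this assay, a 5.2-fold higher number (0.71 log units; beyond the scatter) from compound 2 to compound 1 and a 2.1-fold higher number (0.31 log units; beyond the scatter) from compound 3 to compound 4, 2.5-fold (0.40 log units) apart, within the scatter of two such steps This rests on only two pairs in one cell assay and does not show that the step would hold on any further core, nor does it give a cause for the step.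

The compounds shown leave open what an isopropyl or a benzyl group would give on that amide-type nitrogen. On these data alone, whether a longer chain bearing the hydroxamic acid would keep the same step also remains open.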